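Trading Bromo for Fluoro on an Aromatic Carbon

The source may hold more compounds than are shown below. What is called first, only, known or untested is meant among the compounds shown, and "the series" means these compounds.

In an ADME assay on HEK293 cells (Homo sapiens) for cytotoxicity, read by MTT assay, with a stated time of 72 h (a lower number here means a stronger inhibitor, a higher number a weaker inhibitor), compound 1 `COc1cccc(C(=O)N2CCN(CC(=O)N3CCN(CCCc4c[nH]c5ccc(F)cc45)CC3)CC2)c1` gives 87100 nM and compound 2 `O=C(CN1CCN(C(=O)c2cccc(Br)c2)CC1)N1CCN(CCCc2c[nH]c3ccc(F)cc23)CC1` gives 40600 nM. Among the measured compounds shown here, compound 2 therefore holds the lower of the two numbers measured so far, making it the stronger inhibitor of the pair.

Compound 3 `O=C(CN1CCN(C(=O)c2cccc(F)c2)CC1)N1CCN(CCCc2c[nH]c3ccc(F)cc23)CC1` keeps the rest of compound 2 and alters one group: fluoro in place of bromo on an aromatic carbon. Put simply, the change turns 3-bromophenyl into 3-fluorophenyl.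

For the measured compounds named here, only one measured step bears on this swap, and it concerns the same aromatic carbon. With bromo in place of methoxy, the number moved by a 2.1-fold lower number from compound 1 to compound 2 (0.33 log units; beyond the scatter), a modest step just beyond the scatter. Going by the values given here, no fluoro compound has been measured, so this single step is a thin guide to size and direction. Since compound 2 has the lower value, at 40600 nM, a swap away from bromo seems more likely to raise the number than to lower it. The expected change is small, at a 1.6-fold higher number from compound 2 to compound 3 (0.20 log units; within the scatter), and may not clear the scatter. The estimated value for compound 3 is 65000 nM, with an expected range from 30000 nM to 130000 nM.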

Compound 3, half-maximal inhibitory concentration: 83000 nM
Compound 3: middle estimate off by 1.3-fold (0.11 log units), on the low side; the range from low to high includes it.
By their numbers in this assay, from the lowest: compound 2; then compounds 3 and 1 (each within the scatter of the next).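

In this assay the swap of bromo for fluoro gives a 2.0-fold higher number from compound 2 to compound 3 (0.31 log units; beyond the scatter), so compound 2, with bromo, now stands apart from both of its neighbours, and not just from the methoxy compound. Fluoro and methoxy cannot be told apart on this aromatic carbon, with a 1.0-fold lower number from compound 1 to compound 3 (0.02 log units; within the scatter), so among these three groups only bromo goes with a different number, and the gap is modest, only just beyond the usual scatter. Nothing shown here accounts for why bromo differs from the other two groups.

On these data alone, what stays open is whether bromo is a special case on this carbon or one end of a wider trend, which other groups in the same place, such as chloro, methyl, an amine or a carboxylic acid, could help to settle. As far as these compounds go, all three compounds also share the rest of their structure, so it remains unknown whether the same gap between bromo and fluoro would appear on a different core.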